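Morpholine to piperidine on the longer amide chain

The source may report more compounds than this note shows. Statements on the series, on what has been measured and on what is new or still open speak of the compounds shown alone.

Compound 1 `CCCCc1nc(C)c(CC(=O)N(CC)CC)c(=O)n1Cc1ccc(-c2ccccc2-c2nnn[nH]2)cc1`: 0.089 mg/kg
Compound 2 `CCCCc1nc(C)c(CC(=O)N2CCOCC2)c(=O)n1Cc1ccc(-c2ccccc2-c2nnn[nH]2)cc1`: 0.018 mg/kg
Compound 3 `CCCCc1nc(C)c(CCC(=O)N2CCOCC2)c(=O)n1Cc1ccc(-c2ccccc2-c2nnn[nH]2)cc1`: 0.143 mg/kg

These values come from an in vivo functional assay on the whole organism for inhibition, with Rattus norvegicus as the target; a lower number here means that less compound is needed, a higher number that more compound is needed for the effect. Compound 3 gives 0.143 mg/kg. Its nearest measured neighbour is reached by a 1.6-fold higher number from compound 1 to compound 3 (0.21 log units; within the scatter), and its furthest by a 7.9-fold higher number from compound 2 to compound 3 (0.90 log units; beyond the scatter).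

Compound 4 `CCCCc1nc(C)c(CCC(=O)N2CCCCC2)c(=O)n1Cc1ccc(-c2ccccc2-c2nnn[nH]2)cc1` changes one group: on a carbonyl carbon, piperidin-1-yl takes the place of morpholin-4-yl (piperidin-1-yl in place of morpholin-4-yl on a carbonyl carbon).

The closest evidence is a swap of the amine group on the carbonyl in the shorter-chain pair, a 4.9-fold lower number from compound 1 to compound 2 (0.69 log units; beyond the scatter), where morpholin-4-yl replaced diethylamino. Compound 4 moves the opposite way, from morpholin-4-yl to a group without oxygen, so that step points to a higher number. It is only a loose guide, since diethylamino is not piperidin-1-yl and the chain in compound 4 is longer. The step between the two morpholin-4-yl compounds changes the chain, not the amine group, so it says nothing direct about this swap.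

A rise smaller than the one seen in the shorter-chain pair is therefore expected in this assay. The expected step is a 1.7-fold higher number from compound 3 to compound 4 (0.24 log units; within the scatter). The estimated value for compound 4 is 0.25 mg/kg, with an expected range of 0.08 mg/kg to 0.75 mg/kg.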

Compound 4, dose for half-maximal effect: 0.164 mg/kg
Compound 4: the middle estimate sits 1.5-fold (0.18 log units) above what was measured, and the stated range covers the measured number.
By their numbers in this assay, from the lowest: compound 2; then compounds 1, 3 and 4 (each within the scatter of the next).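

In this assay, on the longer chain, replacing morpholin-4-yl with piperidin-1-yl on a carbonyl carbon removes the ring oxygen without a change that can be told from the scatter (a 1.1-fold higher number from compound 3 to compound 4 (0.06 log units; within the scatter)), unlike the shorter-chain swap of diethylamino for morpholin-4-yl (a 4.9-fold lower number from compound 1 to compound 2 (0.69 log units; beyond the scatter)), though that swap involved a different amine group. Compound 4 also stays well apart from compound 2 (a 9.1-fold higher number from compound 2 to compound 4 (0.96 log units; beyond the scatter)) but cannot be separated from compound 1 (a 1.8-fold higher number from compound 1 to compound 4 (0.27 log units; within the scatter)), so among these four compounds only compound 2 stands apart, and the two longer-chain amides fall with compound 1 rather than with it. The data shown offer no measurement that would explain why the amine ring matters so little on the longer chain.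

Among the compounds shown here, it remains open how piperidin-1-yl would behave on the shorter chain, where the one available pair does show a difference between amine groups. Also open, going by these compounds, is whether other amine groups on the same carbonyl carbon, such as pyrrolidin-1-yl or piperazin-1-yl, would stay as close to compound 3 and compound 4 as these two stay to each other.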